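A few compounds are considered here, and "the series" means these few. Any claim that something is new, unique, unknown or untested is made for them only; others in the source may bear on it.

Working notes on a small set sharing one core. Compound 1 `Nc1ccc(S(=O)(=O)N2CCN(c3ncc(C(O)(C(F)(F)F)C(F)(F)F)cc3C#CC3CC3)CC2)cn1` is the reference point; in an ADME assay (liver) for metabolic stability, with Liver microsome (Rattus norvegicus) as the target, using microsomes and NADPH, with a stated time of 30 min, tested at 1 uM (on this read-out higher numbers stand for fast clearance and lower numbers for slow clearance), compound 1 gives 67 mL.min-1.g-1. Among the three measured compounds it stands second highest. Its nearest neighbour is compound 3 `Nc1ccc(S(=O)(=O)N2CCN(c3ncc(C(O)(C(F)(F)F)C(F)(F)F)cc3-c3cccc(F)c3)CC2)cn1`, which in this assay gives 52 mL.min-1.g-1; the step of a 1.3-fold lower number from compound 1 to compound 3 (0.11 log units; within the scatter) lies within the scatter. Compound 2 `COCC#Cc1cc(C(O)(C(F)(F)F)C(F)(F)F)cnc1N1CCN(S(=O)(=O)c2ccc(N)nc2)CC1` in this assay gives 399 mL.min-1.g-1, the highest number of the set; the step of a 6.0-fold higher number from compound 1 to compound 2 (0.77 log units; beyond the scatter) is beyond the scatter, as is the step of a 7.7-fold lower number from compound 2 to compound 3 (0.88 log units; beyond the scatter).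

Compound 4 `Cc1ccc(-c2cc(C(O)(C(F)(F)F)C(F)(F)F)cnc2N2CCN(S(=O)(=O)c3ccc(N)nc3)CC2)cn1` is not yet measured. Relative to compound 1 the change is 6-methylpyridin-3-yl in place of 2-cyclopropylethynyl on an aromatic carbon. The step that bears most directly on this change is a 1.3-fold lower number from compound 1 to compound 3 (0.11 log units; within the scatter), where an aromatic six-membered ring likewise took the place of the 2-cyclopropylethynyl group on the same aromatic carbon, and the step stayed within the scatter. The step of a 7.7-fold lower number from compound 2 to compound 3 (0.88 log units; beyond the scatter) also ends with an aromatic ring on that carbon and runs toward a lower number, but it starts from a different group, so it carries less weight here. The expectation for compound 4 is therefore a step of a 1.2-fold lower number from compound 1 to compound 4 (0.09 log units; within the scatter), within the scatter. Compound 4 is estimated at 55 mL.min-1.g-1, with a range from 25 mL.min-1.g-1 to 120 mL.min-1.g-1.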

Compound 4, intrinsic clearance in microsomes: 182 mL.min-1.g-1
Compound 4: the middle estimate sits 3.3-fold (0.52 log units) below what was measured, outside the stated range (above it).
By their numbers in this assay, from the lowest: compounds 3 and 1 (each within the scatter of the next); then compound 4; then compound 2.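

On this aromatic carbon, a six-membered aromatic ring in place of 2-cyclopropylethynyl does not by itself keep the number in this assay level, since a 2.7-fold higher number from compound 1 to compound 4 (0.43 log units; beyond the scatter) lies beyond the scatter, while the same kind of replacement in compound 3 stayed within it. The choice of ring therefore counts at this position: a 3.5-fold higher number from compound 3 to compound 4 (0.54 log units; beyond the scatter) is a step between two aromatic rings on the same carbon, and it too lies beyond the scatter. Triple bond versus ring does not sort the set either. The step of a 2.2-fold lower number from compound 2 to compound 4 (0.34 log units; beyond the scatter) leaves the 6-methylpyridin-3-yl compound under the methoxy-bearing alkyne yet over the alkyne compound 1, with compound 3 going against any simple ring rule.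

Between compound 3 and compound 4 the ring nitrogen, the methyl and the fluorine all change at once, so the compounds shown cannot assign the step to any one of them, and a plain pyridin-3-yl or a 3-methylphenyl on this carbon would separate them. Nothing available bears on why these steps differ in size.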